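Swapping fluoro for ethyl on a weak antiproliferative quinazoline

The source may hold more compounds than are shown below. What is called first, only, known or untested is meant among the compounds shown, and "the series" means these compounds.

Within the data shown here, compound 1 `COc1cc2ncnc(Nc3ccc(Br)cc3F)c2cc1OCCCN1CCNCCNCCNCC1` was tested in a functional assay on A549 cells (Homo sapiens) for antiproliferative activity, read by MTT assay, with a stated time of 72 h (on this read-out lower numbers stand for stronger inhibition and higher numbers for weaker inhibition), and gave 15200 nM, which is the lowest of the two numbers measured so far. Among the measured compounds shown here, its only measured neighbour, compound 2 `COc1cc2ncnc(Nc3cccc(C(F)(F)F)c3)c2cc1OCCCN1CCNCCNCCNCC1`, gave 15700 nM in this assay, and the step of a 1.0-fold higher number from compound 1 to compound 2 (0.01 log units; within the scatter) shows that replacing the whole anilino ring left the number essentially unchanged. Compound 3 `CCc1cc(Br)ccc1Nc1ncnc2cc(OC)c(OCCCN3CCNCCNCCNCC3)cc12` has not yet been measured; it differs from compound 1 by ethyl in place of fluoro on an aromatic carbon. For the measured compounds named here, no measured step swaps fluoro for ethyl at this position, so the only guide is the step from compound 1 to compound 2, which stayed within the scatter despite a larger change. A step within the scatter is therefore expected, a 1.0-fold lower number from compound 1 to compound 3 (0.01 log units; within the scatter). Compound 3 is estimated to give about 15000 nM in this assay, within a range from 6000 nM to 40000 nM.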

Compound 3, half-maximal inhibitory concentration: > 50000 nM
Compound 3: a limit, no number (the forecaster's own chance of this, stated with the estimate: 10%); at least 3.3-fold (0.52 log units) between middle value and limit.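

In this assay compound 3 gives > 50000 nM, which is a limit of the assay and not a number: the limit of > 50000 nM in this assay, at which 1 of the 3 values shown sits. Even with that limit, ethyl in place of fluoro on this aromatic carbon gives an at least 3.2-fold higher number from compound 1 to compound 3 (0.51 log units; beyond the scatter), so the change of one small group moves the read-out beyond the scatter. The same holds against the other measured neighbour, with an at least 3.1-fold higher number from compound 2 to compound 3 (0.50 log units; beyond the scatter), whereas the earlier change of ring substituents gave only a 1.0-fold higher number from compound 1 to compound 2 (0.01 log units; within the scatter), so this position responds to a change in a way the earlier pair did not reveal.

The true size of the step cannot be read from a limit, and the compounds shown give no cause for it. From the compounds shown here alone, whether methyl, methoxy or an amine on this aromatic carbon would stay close to compound 1 remains open.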